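Methoxy in place of fluoro: a first estimate

The source may report more compounds than this note shows. Statements on the series, on what has been measured and on what is new or still open speak of the compounds shown alone.

Measured so far, in a functional assay on NCI-H460 cells (Homo sapiens) for cytotoxicity, read by MTT assay, with a stated time of 68 h; a higher number here means a weaker inhibitor, a lower number a stronger inhibitor:
compound 1 `O=C(Nc1cccc(-c2ccc(F)cc2)c1)C(Cl)Cl`: > 50000 nM
compound 2 `O=C(Nc1cccc(-c2cccc(Cl)c2)c1)C(Cl)Cl`: > 50000 nM

Both entries are limits of the assay rather than numbers. Compound 1 stands at the limit > 50000 nM. Compound 2 likewise returns only the limit > 50000 nM. Hence (the limit of > 50000 nM in this assay, at which 2 of the 2 values shown sit), and compound 1 cannot be placed against any numbered value.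

Compound 3 `COc1ccc(-c2cccc(NC(=O)C(Cl)Cl)c2)cc1` differs from compound 1 by methoxy in place of fluoro on an aromatic carbon. Among the compounds with values here, no step between measured compounds exists, so the effect of this change is untested here. The expected step of a number no higher from compound 1 to compound 3 (the limit leaves the size open) is none beyond the scatter. Compound 3 is estimated at 50000 nM, within 20000 nM to 120000 nM, most probably again as a limit.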

Compound 3, half-maximal inhibitory concentration: 43300 nM
Beside the measured number, compound 3's estimate is 1.2-fold (0.06 log units) above it; the measured number falls inside the stated range.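

Within the data shown here, compound 3 gives the first numbered value of the series, 43300 nM in this assay, with methoxy in place of fluoro, para to a large group. Compound 1 returns only a limit. As far as these compounds go, the step reads an at least 1.1-fold lower number from compound 1 to compound 3 (0.06 log units; that floor lies within the scatter), and its true size stays open, since one end of it is a limit and not a number. The series still rests largely on limits: the limit of > 50000 nM in this assay, at which 2 of the 3 values shown sit.

From the compounds shown here alone, whether an amine, a carboxylic acid or an ethoxy group at this position would give a lower number remains open.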